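The compounds below may be only part of what the source reports. "The series", "measured", "known", "first", "only" and "open" are said of these compounds alone.

Compound 1 `O=C(Nc1ccc(Cl)c(-c2nnc3c(Cl)cccn23)c1)c1ccc(Cl)cc1` is a weak inhibitor in a functional assay on MCF7 cells (Homo sapiens) for antiproliferative activity, read by MTT assay, with a stated time of 72 h (a lower number here means a stronger inhibitor, a higher number a weaker inhibitor), giving 58400 nM. Compound 2 `Cc1cc(Cl)ccc1C(=O)Nc1ccc(Cl)c(-c2nnc3c(Cl)cccn23)c1` reaches only a limit of that assay, > 100000 nM. The single measured step, an at least 1.7-fold higher number from compound 1 to compound 2 (0.23 log units; that floor lies within the scatter), is bounded by that limit (the limit of > 100000 nM in this assay, at which 1 of the 2 values shown sits), so compound 2 stands at the weak end of the numbers shown. Compound 3 `O=C(Nc1ccc(Cl)c(-c2nnc3c(Cl)cccn23)c1)c1c(F)cccc1Cl` differs from compound 2 by 2-chloro-6-fluorophenyl in place of 4-chloro-2-methylphenyl on a carbonyl carbon. Among the measured compounds shown here, no measured step matches this change; both known values are weak. The expected step, an at least 1.2-fold lower number from compound 2 to compound 3 (0.09 log units; that floor lies within the scatter), is none beyond the scatter in this assay. Compound 3 is therefore estimated at 80000 nM, within 20000 nM to 300000 nM.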

Compound 3, half-maximal inhibitory concentration: > 100000 nM
Compound 3: only a limit was reported; the forecaster's own chance of this, stated with the estimate: 45%; middle value at least 1.2-fold (0.09 log units) away from the limit.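

With 2-chloro-6-fluorophenyl on the carbonyl carbon, compound 3 also reaches only a limit in this assay, > 100000 nM. Set against 4-chlorophenyl, this change gives an at least 1.7-fold higher number from compound 1 to compound 3 (0.23 log units; that floor lies within the scatter), so no real loss of activity is established. The step between compound 2 and compound 3 cannot be read, and the limit now holds more of the series: the limit of > 100000 nM in this assay, at which 2 of the 3 values shown sit.

Still open, on these data alone, is whether any group at this place can give a clearly lower number than compound 1, at 58400 nM. An aromatic ring carrying an amine or a carboxylic acid, or a longer chain, could answer that.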